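Methylpiperazine on the anilide side and kinetic solubility

The source may hold more compounds than are shown below. What is called first, only, known or untested is meant among the compounds shown, and "the series" means these compounds.

Compound 1 `CN(Cc1ccc(F)cc1)c1cc(C(=O)Nc2ccccc2)ncn1` and compound 2 `CN(Cc1ccc(C(F)(F)F)nc1)c1cc(C(=O)Nc2ccccc2)ncn1` differ in their cores; the difference between the two cores is not broken down here. In a physicochemical assay for solubility, using the shake flask method, measured as kinetic solubility, with a stated time of 2 h, at pH 7.4 (a higher number here means a more soluble compound, a lower number a less soluble compound), compound 1 gives < 5000 nM, which is a limit of the assay and not a number. Compound 2 also sits at a limit in this assay, giving < 5000 nM. Compound 3 `CN1CCN(c2ccc(NC(=O)c3cc(N(C)Cc4ccc(C(F)(F)F)nc4)ncn3)cc2)CC1` carries 4-methylpiperazin-1-yl in place of hydrogen on an aromatic carbon and gives 165000 nM in this assay, a step of an at least 33-fold higher number from compound 2 to compound 3 (1.51 log units; beyond the scatter). Compound 4 `CN1CCN(c2cccc(NC(=O)c3cc(N(C)Cc4ccc(F)cc4)ncn3)c2)CC1` carries 4-methylpiperazin-1-yl in place of hydrogen on an aromatic carbon; this is the same kind of change as that leading to compound 3, but here the group sits meta to a large group rather than para to a large group. The step from compound 1 to compound 4 in this assay is expected to be about an at least 24-fold higher number from compound 1 to compound 4 (1.38 log units; beyond the scatter), resting on an at least 33-fold higher number from compound 2 to compound 3 (1.51 log units; beyond the scatter) and on (the limit of < 5000 nM in this assay, at which 2 of the 3 values shown sit), at which compound 1 sits. Compound 4 is therefore estimated at 120000 nM, with an expected range of 30000 nM to 400000 nM.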

Compound 4, solubility: 74000 nM
Estimate against measurement, compound 4: 1.6-fold (0.21 log units) above; measured number inside the range.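

In this assay, 4-methylpiperazin-1-yl in place of hydrogen on an aromatic carbon carries over to the core of compound 1, giving an at least 14-fold higher number from compound 1 to compound 4 (1.17 log units; beyond the scatter), in the same direction as an at least 33-fold higher number from compound 2 to compound 3 (1.51 log units; beyond the scatter). Compound 1 gives < 5000 nM, a limit of the assay and not a number, and the other step also starts from a limit: the limit of < 5000 nM in this assay, at which 2 of the 4 values shown sit. The two steps differ in core and in the place of the group, which in compound 4 sits meta to a large group, so their sizes cannot be compared and neither difference can be assessed alone.

On these data alone, whether each core gives a step of this kind with the group in the other place remains open. Also open, as far as these compounds go, is whether morpholine or a carboxylic acid in place of hydrogen on that aromatic carbon gives a similar step.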